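Swapping the halogenated phenyl on an aminothiophene core

A few compounds are considered here, and "the series" means these few. Any claim that something is new, unique, unknown or untested is made for them only; others in the source may bear on it.

Of the compounds shown here, three sharing one core have been measured in a functional assay on CHO cells for agonist activity at adenosine receptor A1 (Homo sapiens), read by fluorescence and ERK phosphorylation, with stated times of 30 min and 1.5 h, tested at 3 uM; a higher number here means a stronger effect of the compound at the concentration tested, a lower number a weaker effect. Compound 1 `Nc1scc(-c2ccc(I)cc2)c1C(=O)c1ccccc1` gives 51%. Compound 2 `Nc1scc(-c2ccc(F)cc2)c1C(=O)c1ccc(Cl)cc1` gives 62%, and compound 3 `Nc1scc(-c2cccc(Br)c2)c1C(=O)c1ccc(Cl)cc1` gives 62%. Compound 3 and compound 2 therefore sit at the same level within the scatter, while compound 1 lies lower than compound 3 by a gap beyond the scatter.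

Compound 4 `Nc1scc(-c2ccc(I)cc2)c1C(=O)c1ccc(Cl)cc1` differs from compound 3 in one place: 4-iodophenyl in place of 3-bromophenyl on an aromatic carbon. Among the compounds with values here, the only single-change step available is no change at the digits printed from compound 2 to compound 3 (within the scatter), which shows that exchanging one halogenated phenyl for another at this position left the number unchanged. Compound 1 also carries 4-iodophenyl at that position, but it differs from compound 4 in a second place as well, so its value of compound 1 can only hint that a somewhat lower number is possible. The step of a number 4 percentage points lower from compound 3 to compound 4 (within the scatter) is therefore expected to be small, leaning slightly downward. Compound 4 is estimated at 58%, within a range from 42% to 72%.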

Compound 4, a percentage reported as activity, at one concentration (the size of the read-out at that concentration, not a potency): 54%
Compound 4: middle estimate off by 4 percentage points, on the high side; low and high end bracket the measured number.
By their numbers in this assay, from the lowest: compounds 1, 4, 2 and 3 (each within the scatter of the next, the first and the last beyond it).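

In this assay, 4-iodophenyl in place of 3-bromophenyl gives a number 8 percentage points lower from compound 3 to compound 4 (within the scatter) and so joins the earlier exchange of halogenated phenyl groups at this position in staying within the scatter, now with a change in both the halogen and where it sits on the phenyl. Iodo in place of fluoro gives a number 8 percentage points lower from compound 2 to compound 4 (within the scatter) and chloro in place of hydrogen gives a number 3 percentage points higher from compound 1 to compound 4 (within the scatter) as well, so neither single change separates its pair, although compound 1 and compound 3 do lie apart beyond the scatter. Nothing measured here explains these small steps.

On these data alone, whether a non-halogen group on this phenyl, such as an amine or a carboxylic acid, would shift the number beyond the scatter stays open. Since each number comes from a single concentration, these results also leave the potency of the compounds open.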